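Working notes: from compound 2 to compound 3

A few compounds are considered here, and "the series" means these few. Any claim that something is new, unique, unknown or untested is made for them only; others in the source may bear on it.

For the measured compounds named here, in a physicochemical assay for lipophilicity, using the shake flask method (a higher number here means a more lipophilic compound, a lower number a more polar compound), compound 1 (`CC(C)(C)OC(=O)N/N=C/c1c(N)ncnc1Oc1ccc(NC(=O)C2(C(=O)Nc3ccc(F)cc3)CC2)cc1F`) gives 3.7 and compound 2 (`Nc1ncnc(Oc2ccc(NC(=O)C3(C(=O)Nc4ccc(F)cc4)CC3)cc2F)c1/C=N/OCCCN1CCCC1`) gives 3.82 so the only two measured values lie within the scatter of each other. Going by the values given here, compound 3 (`CC(O)CO/N=C/c1c(N)ncnc1Oc1ccc(NC(=O)C2(C(=O)Nc3ccc(F)cc3)CC2)cc1F`) has no measurement yet in this assay and differs from compound 2 by 1-hydroxyethyl in place of 2-(pyrrolidin-1-yl)ethyl on a saturated chain carbon bound to an oxygen on a saturated chain carbon bound to an oxygen. Cut one bond further out, the same difference reads 3-(pyrrolidin-1-yl)propoxy to 2-hydroxypropoxy.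

Among the compounds with values here, one measured step bears on this change, and only loosely: a number 0.12 log units higher from compound 1 to compound 2 (within the scatter) with 3-(pyrrolidin-1-yl)propoxy in place of (tert-butoxycarbonyl)amino on a double-bonded nitrogen. That step shows that a large exchange at this place need not move the number beyond the scatter. Within the data shown here, no measured pair removes the five-membered ring or brings in the hydroxy group, so the direction rests on the structural change alone. A modest move to a lower number is expected, though one within the scatter cannot be excluded. The estimated step is a number 0.52 log units lower from compound 2 to compound 3 (beyond the scatter). For compound 3 the estimated value is 3.3 with an expected range of 2.8 to 3.8 (an estimate only).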

Compound 3, partition coefficient: 2.75
Compound 3: middle estimate off by 0.55 log units, on the high side; the whole stated range lies above it.
By their numbers in this assay, from the lowest: compound 3; then compounds 1 and 2 (each within the scatter of the next).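

In this assay compound 1 and compound 2 stayed within the scatter of each other, but this place on the double-bonded nitrogen now shows a clear response: 2-hydroxypropoxy gives a number 1.07 log units lower from compound 2 to compound 3 (beyond the scatter) and a number 0.95 log units lower from compound 1 to compound 3 (beyond the scatter) when set against the other group. The number at this place therefore does not follow from the size of the exchange alone, since (tert-butoxycarbonyl)amino and 3-(pyrrolidin-1-yl)propoxy give values within the scatter of each other, while only the compound carrying the hydroxy group stands apart. Nothing measured alongside these values accounts for the size of the two steps.

The compounds shown do not separate the loss of the five-membered ring from the gain of the hydroxy group, as both changes occur together from compound 2 to compound 3. A simple dimethylamino group on the same propoxy chain, or a longer chain ending in a hydroxy group, would isolate one of these two parts of the exchange.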